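Working notes: one substituent change on the shared core

The compounds below may be only part of what the source reports. "The series", "measured", "known", "first", "only" and "open" are said of these compounds alone.

Measured compounds:
compound 1 `CC(C)N1CCN(CCN2CCC(c3cn(-c4ccc(F)cc4)c4cc(C(F)(F)F)ccc34)CC2)C1=O` — 91 nM
compound 2 `CC(C)N1CCN(CCN2CCC(c3cn(-c4ccc(F)cc4)c4cc(F)ccc34)CC2)C1=O` — 13 nM

Both were tested in an assay on cell membranes for displacement of a labelled ligand from Adrenergic receptor alpha-1 (Rattus norvegicus); a lower number here means a stronger inhibitor, a higher number a weaker inhibitor. Compound 2 gives the lowest of the two numbers in this assay; its nearest neighbour is compound 1, and the step of a 7.0-fold lower number from compound 1 to compound 2 (0.85 log units; beyond the scatter) came with fluoro in place of trifluoromethyl on an aromatic carbon. Compound 3 `CC(C)c1ccc2c(C3CCN(CCN4CCN(C(C)C)C4=O)CC3)cn(-c3ccc(F)cc3)c2c1` carries isopropyl in place of fluoro on an aromatic carbon. For the measured compounds named here, the only measured step that bears on this position is a 7.0-fold lower number from compound 1 to compound 2 (0.85 log units; beyond the scatter): the smaller group there went with a lower number, beyond the scatter. Isopropyl brings more heavy atoms than fluoro, so a move in the reverse direction is expected, though the measured step concerned trifluoromethyl and not isopropyl, and its size is only a guide. Compound 3 is therefore expected to give 60 nM in this assay, within 20 nM to 200 nM, an expected step of a 4.6-fold higher number from compound 2 to compound 3 (0.66 log units; beyond the scatter).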

Compound 3, half-maximal inhibitory concentration: 730 nM
Compound 3: middle estimate off by 12-fold (1.09 log units), on the low side; the whole stated range lies below it.
By their numbers in this assay, from the lowest: compound 2; then compound 1; then compound 3.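

In this assay isopropyl in place of fluoro goes with a 56-fold higher number from compound 2 to compound 3 (1.75 log units; beyond the scatter) and isopropyl in place of trifluoromethyl goes with an 8.0-fold higher number from compound 1 to compound 3 (0.90 log units; beyond the scatter) so both steps into isopropyl lie beyond the scatter, the first large and the second modest. For the compounds shown here, the earlier pair ranked only two fluorine-bearing groups, whereas both now give lower numbers than the all-carbon isopropyl, and the order at this position runs fluoro, trifluoromethyl, isopropyl. Nothing measured here accounts for this order.

The compounds shown leave open whether the high number is particular to isopropyl or extends to other carbon groups such as methyl or tert-butyl, and where a chlorine atom, a methoxy group or an amine would fall. On these data alone, it also remains open whether the same order holds when the rest of the shared core is changed.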